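The compounds below may be only part of what the source reports. "The series", "measured", "known", "first", "only" and "open" are said of these compounds alone.

Measured compounds:
- compound 1 `CCC(C)(C)Cc1c[nH]c(CCc2ccc(-n3cccn3)cc2)n1` gives 106 nM in a functional assay on HEK293 cells for agonist activity at Bombesin receptor subtype-3 (Homo sapiens), read by luminescence and calcium flux, with a stated time of 10 min; a higher number here means that more compound is needed for the effect, a lower number that less compound is needed
- compound 2 `CCC(C)(C)Cc1c[nH]c(CCc2ccc(-n3ncnn3)cc2)n1` gives 89 nM in this assay
- compound 3 `CCC(C)(C)Cc1c[nH]c(CCc2ccc(-n3ccnn3)cc2)n1` gives 93 nM in this assay

Compound 3 stands second highest of the three numbers; its nearest neighbour is compound 2, its furthest compound 1, and every pairwise step among the three lies within the scatter: a 1.2-fold lower number from compound 1 to compound 2 (0.08 log units; within the scatter), a 1.1-fold lower number from compound 1 to compound 3 (0.06 log units; within the scatter), a 1.0-fold higher number from compound 2 to compound 3 (0.02 log units; within the scatter).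

The next compound, compound 4 `CCC(C)(C)Cc1c[nH]c(CCc2ccc(-c3cnccn3)cc2)n1`, differs from compound 3 in one place: pyrazin-2-yl in place of 1H-1,2,3-triazol-1-yl on an aromatic carbon. The three measured steps all swap one five-membered azole for another at this same position and none of them moves beyond the scatter. No measured step covers a six-membered ring joined through carbon, so the new change is not directly covered, but the observed insensitivity of this position to the identity of the attached heteroaryl gives no reason to expect a large step in either direction in this assay.

Compound 4 is therefore estimated at 110 nM, with a range from 40 nM to 320 nM. The expected step from compound 3 is a 1.2-fold higher number from compound 3 to compound 4 (0.07 log units; within the scatter), widened in range because the ring type itself is new.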

Compound 4, half-maximal effective concentration: 100 nM
Compound 4: middle estimate off by 1.1-fold (0.04 log units), on the high side; low and high end bracket the measured number.
By their numbers in this assay, from the lowest: compounds 2, 3, 4 and 1 (each within the scatter of the next).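

In this assay, with a 1.1-fold higher number from compound 3 to compound 4 (0.03 log units; within the scatter) and with a 1.1-fold higher number from compound 2 to compound 4 (0.05 log units; within the scatter) and with a 1.1-fold lower number from compound 1 to compound 4 (0.03 log units; within the scatter) the pyrazin-2-yl group stays level with all three groups built on a five-membered aromatic ring. The indifference seen among the five-membered rings on this aromatic carbon therefore extends, across these four compounds, to a six-membered aromatic ring with 2 hetero atoms attached through carbon, so neither ring size nor the attaching atom separates the compounds here. No measurement on hand accounts for this flat response.

From the compounds shown here alone, all four compounds carry an aromatic ring with hetero atoms at this place, so the effect of an unsubstituted phenyl, an amine, a carboxylic acid or a longer chain there remains open. Going by these compounds, with the rest of the core unchanged throughout, it also remains open whether this flat response survives a change elsewhere in the core.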